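Cytotoxicity notes on one amide series

The source may hold more compounds than are shown below. What is called first, only, known or untested is meant among the compounds shown, and "the series" means these compounds.

Three compounds have been measured in an ADME assay on HepG2 cells (Homo sapiens) for cytotoxicity, read by CellTiter-Glo and resazurin assay, with a stated time of 72 h; on this read-out lower numbers stand for an effect already at smaller amounts and higher numbers for an effect only at larger amounts of compound:
compound 1 `COc1cccc(-c2ccc(C(=O)N(Cc3cccc(OCCCCCC(=O)O)c3)C(C)C)cc2)c1` gives > 26000 nM
compound 2 `CC(C)N(Cc1cccc(OCCCCCC(=O)O)c1)C(=O)c1ccc(-c2ccc3[nH]ccc3c2)cc1` gives > 26000 nM
compound 3 `CCOC(=O)CCCCCOc1cccc(CN(C(=O)c2ccc(-c3cccc(OC)c3)cc2)C(C)C)c1` gives > 21000 nM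

Each of these three values is a limit of this assay and not a number. Compound 1 and compound 2 sit at the limit of > 26000 nM in this assay, at which 2 of the 3 values shown sit, compound 3 at the limit of > 21000 nM in this assay, at which 1 of the 3 values shown sits. Nothing in the set has reached a readable value.

The change from compound 1 to compound 2 is 1H-indol-5-yl in place of 3-methoxyphenyl on an aromatic carbon. Its step, a step that the two limits leave unreadable from compound 1 to compound 2, cannot be sized. The cores of compound 1 and compound 3 differ by ethyl in place of hydrogen on an oxygen next to a carbonyl group, and the step that the two limits leave unreadable from compound 1 to compound 3 is likewise unreadable.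

Compound 4 `CCOC(=O)CCCCCOc1cccc(CN(C(=O)c2ccc(-c3ccc4[nH]ccc4c3)cc2)C(C)C)c1` is not yet measured. It differs from compound 3 by 1H-indol-5-yl in place of 3-methoxyphenyl on an aromatic carbon; this is the same change as that between compound 1 and compound 2, at a place described in the same words.

Compound 4 is expected to show a step that the limit leaves unreadable from compound 3 to compound 4, since a step that the two limits leave unreadable from compound 1 to compound 2 gave no readable movement and every value in the set is a limit. Compound 4 is therefore estimated at 30000 nM, most likely again reported only as a limit, with a range from 15000 nM to 100000 nM.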

Compound 4, half-maximal effective concentration: > 26000 nM
Compound 4: a limit, no number; the forecaster's own chance of this, stated with the estimate: 85%; the middle value lies beyond the limit too.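

In this assay compound 4 gives > 26000 nM, a limit and not a number, so no step can be read from compound 3 or compound 2 to compound 4. The compounds shown leave open whether either change, 1H-indol-5-yl in place of 3-methoxyphenyl or ethyl in place of hydrogen, moves the value at all.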